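From (4-fluorobenzyl)sulfanyl to benzylsulfanyl: compound 4

A few compounds are considered here, and "the series" means these few. Any claim that something is new, unique, unknown or untested is made for them only; others in the source may bear on it.

Of the compounds shown here, three have been measured in a functional assay on MKN-45 cells (Homo sapiens) for cytotoxicity, read by MTT assay, with a stated time of 48 h (a higher number here means a weaker inhibitor, a lower number a stronger inhibitor), and each of them stands at a limit rather than at a number.

Compound 1 `COc1cc(-c2nnc(SCc3ccccc3)n2/N=C/c2ccccc2)cc(OC)c1OC` gives > 200000 nM, a limit of the assay.
Compound 2 `COc1ccc(/C=N/n2c(SC)nnc2-c2cc(OC)c(OC)c(OC)c2)c(OC)c1` gives > 200000 nM, also a limit.
Compound 3 `COc1ccc(/C=N/n2c(SCc3ccc(F)cc3)nnc2-c2cc(OC)c(OC)c(OC)c2)c(OC)c1` gives > 200000 nM, again a limit.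

Compound 3 thus stands at the limit of > 200000 nM in this assay, at which 3 of the 3 values shown sit. Within the data shown here, the only measured step that changes a single place, a step that the two limits leave unreadable from compound 2 to compound 3, cannot be read; both of its ends are limits.

Compound 4 `COc1ccc(/C=N/n2c(SCc3ccccc3)nnc2-c2cc(OC)c(OC)c(OC)c2)c(OC)c1` is compound 3 with one change: hydrogen in place of fluoro on an aromatic carbon. Among the measured compounds shown here, no measured step covers this exact difference, and the one step that brings in the whole 4-fluorophenyl group gives no readable size. Nothing among the three measured values shows any compound departing from the limit, so the expectation for compound 4 is that it will most likely sit there as well, with no step beyond the scatter. The estimate for compound 4 in this assay is 250000 nM, with a range from 100000 nM to 1000000 nM. The step from compound 3 to compound 4 that this estimate implies is a step that the limit leaves unreadable from compound 3 to compound 4, expected to be none beyond the scatter.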

Compound 4, half-maximal inhibitory concentration: 49000 nM
For compound 4 the middle estimate is 5.1-fold (0.71 log units) above the measured one; measured number below the stated range.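

In this assay, compound 4 is the only one of the four that gives a number rather than a limit, so the aromatic carbon that carries fluoro in compound 3 proves sensitive to this change: hydrogen in place of fluoro gives an at least 4.0-fold lower number from compound 3 to compound 4 (0.61 log units; beyond the scatter). The same compound also gives the first readable sizes for the two other places, with phenyl in place of hydrogen on the saturated chain carbon bound to a sulfur giving an at least 4.0-fold lower number from compound 2 to compound 4 (0.61 log units; beyond the scatter), and 2,4-dimethoxyphenyl in place of phenyl on the carbon with a double bond to nitrogen giving an at least 4.0-fold lower number from compound 1 to compound 4 (0.61 log units; beyond the scatter). Among the compounds shown, a measurable number appears only where benzylsulfanyl and 2,4-dimethoxyphenyl stand together without fluoro, while the other three compounds stay at a limit: the limit of > 200000 nM in this assay, at which 3 of the 4 values shown sit.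

Among these compounds, the one step with a limit at both ends cannot be read, and all three readable steps give only a minimum size, so the full size of each remains unknown. The compounds shown also leave open whether chloro, methyl or methoxy on that aromatic carbon would behave like fluoro or like hydrogen, and whether a longer chain between the sulfur and the phenyl would keep the number seen for compound 4.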